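This account rests on a few compounds, and the source may have more. Where it says the series, first, only, none or still open, it means among the compounds named here.

Measured so far:
- compound 1 `Oc1ccc(-c2nc3cc(C(F)(F)F)ccc3[nH]2)cc1` gives 17000 nM in an ADME assay on MT4 cells (Homo sapiens) for cytotoxicity, read by MTT assay, with a stated time of 96 h; a higher number here means that more compound is tolerated, a lower number that less compound is tolerated
- compound 2 `CCN(CC)CC(=O)Nc1ccc(-c2nc3cc(C(F)(F)F)ccc3[nH]2)cc1` gives 8000 nM in this assay

Of these two numbers, compound 2 has the lower one; its nearest neighbour is compound 1, and the step of a 2.1-fold lower number from compound 1 to compound 2 (0.33 log units; beyond the scatter), which is beyond the scatter, separates them. Compound 3 `CC(=O)Nc1ccc(-c2nc3cc(C(F)(F)F)ccc3[nH]2)cc1`, not yet measured, differs from compound 2 by hydrogen in place of diethylamino on a saturated chain carbon bound to a carbonyl carbon. Among the compounds with values here, the only measured step, a 2.1-fold lower number from compound 1 to compound 2 (0.33 log units; beyond the scatter), swaps a hydroxy for the whole (((diethylamino)methyl)carbonyl)amino group, so the part of that change which the diethylamino alone carries is unknown; compound 3, an acetamido analogue, is expected to land between the two measured neighbours. In this assay compound 3 is therefore estimated at 12000 nM, with a range from 6000 nM to 25000 nM, which means an expected step of a 1.5-fold higher number from compound 2 to compound 3 (0.18 log units; within the scatter), probably within the scatter.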

Compound 3, half-maximal cytotoxic concentration: 19000 nM
For compound 3 the middle estimate is 1.6-fold (0.20 log units) below the measured one; the measured number falls inside the stated range.
By their numbers in this assay, from the lowest: compound 2; then compounds 1 and 3 (each within the scatter of the next).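

Taking the diethylamino off the saturated chain carbon bound to a carbonyl carbon, which leaves acetamido, raises the concentration tolerated in this assay (a 2.4-fold higher number from compound 2 to compound 3 (0.38 log units; beyond the scatter)). The lower number of compound 2 therefore goes with the diethylamino rather than with the amide link alone, while acetamido in place of hydroxy on the aromatic carbon stays within the scatter (a 1.1-fold higher number from compound 1 to compound 3 (0.05 log units; within the scatter)). No measurement is available to explain what the diethylamino does in these cells.

Still open, going by these compounds, is whether this step belongs to diethylamino in particular or would also appear with another amine on the same carbon, such as dimethylamino or piperidine. On these data alone, it is also open whether a longer chain between the carbonyl and the amine would move the number further.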